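From an Ester Chain to an Imidazole Ring

The source may report more compounds than this note shows. Statements on the series, on what has been measured and on what is new or still open speak of the compounds shown alone.

Of the compounds shown here, three built on one shared core have been tested in a functional assay (aorta) with Rattus norvegicus as the target; on this read-out lower numbers stand for stronger inhibition and higher numbers for weaker inhibition. Compound 1 `CCOC(=O)CCCN(c1ccccc1)[C@H]1c2cc(C#N)ccc2OC(C)(C)[C@@H]1O` gives > 30000 nM, which is a limit of the assay rather than a measured number. Compound 2 `CCOC(=O)CN(c1ccc(Cl)cc1)[C@H]1c2cc(C#N)ccc2OC(C)(C)[C@@H]1O` likewise reaches only > 30000 nM, again a limit. Within the data shown here, compound 3 `CCOC(=O)C(=O)N(c1ccc(F)cc1)[C@H]1c2cc(C#N)ccc2OC(C)(C)[C@@H]1O` is the one compound with a number, giving 43000 nM. Compound 1 therefore stands at the limit of > 30000 nM in this assay, at which 2 of the 3 values shown sit, so all that is known of it is that its inhibition is weak.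

Compound 4 `CC1(C)Oc2ccc(C#N)cc2[C@H](N(Cc2ncc[nH]2)c2ccccc2)[C@H]1O` has not yet been measured. It differs from compound 1 in one place: 1H-imidazol-2-yl in place of 2-(ethoxycarbonyl)ethyl on a saturated chain carbon bound to a nitrogen on an aromatic ring. Among the measured compounds shown here, no measured pair in this set shows what such a change does, so there is no basis to expect a shift beyond the usual scatter in either direction; the step expected from compound 1 to compound 4 is a number no higher from compound 1 to compound 4 (the limit leaves the size open). Compound 4 is accordingly estimated at 30000 nM, with a plausible span from 6000 nM to 100000 nM, and a fair chance that this assay again reports only a limit.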

Compound 4, half-maximal inhibitory concentration: > 30000 nM
Compound 4: a limit, no number (the forecaster's own chance of this, stated with the estimate: 50%); the middle value sits exactly at the limit.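

Compound 4 gives > 30000 nM, which is a limit of this assay and not a number. Among these compounds, compound 1 also sits at a limit, so no step between compound 1 and compound 4 can be read. The compounds shown leave open whether 1H-imidazol-2-yl in place of 2-(ethoxycarbonyl)ethyl changes inhibition at all.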